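The source may hold more compounds than are shown below. What is called first, only, known or untested is meant among the compounds shown, and "the series" means these compounds.

Working notes on a small set of acetylated sugar thiosemicarbazides carrying a benzimidazole acetyl hydrazide tail, all examined in a functional assay on Bel-7402 cells (Homo sapiens) for cytotoxicity, read by MTT assay, with a stated time of 48 h; a lower number here means that less compound is needed, a higher number that more compound is needed for the effect.

Compound 1 `CC(=O)O[C@@H]1[C@@H](OC(C)=O)[C@@H](O)[C@@H](CO)O[C@H]1NC(=S)NNC(=O)Cn1cnc2ccccc21` is the parent. In this assay compound 1 gives only a limit, > 200000 nM. Compound 2 `CC(=O)O[C@@H]1[C@@H](OC(C)=O)[C@@H](O)CO[C@H]1NC(=S)NNC(=O)Cn1cnc2ccccc21` differs from compound 1 by hydrogen in place of hydroxymethyl on a saturated ring carbon. In this assay compound 2 likewise gives only a limit, > 200000 nM. The step that the two limits leave unreadable from compound 1 to compound 2 therefore cannot be sized, because both values sit at the limit of > 200000 nM in this assay, at which 2 of the 3 values shown sit.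

Compound 3 `COc1ccc(C(=O)Nc2nc3ccccc3n2CC(=O)NNC(=S)N[C@@H]2O[C@H](CO)[C@H](O)[C@H](OC(C)=O)[C@H]2OC(C)=O)cc1` carries a different core, differing from compound 1 by ((4-methoxyphenyl)carbonyl)amino in place of hydrogen on an aromatic carbon. In this assay, among the measured compounds shown here, compound 3 gives 76400 nM, the one real number in the set, and the step of an at least 2.6-fold lower number from compound 1 to compound 3 (0.41 log units; beyond the scatter) is the only readable change.

Compound 4 `COc1ccc(C(=O)Nc2nc3ccccc3n2CC(=O)NNC(=S)N[C@@H]2OC[C@H](O)[C@H](OC(C)=O)[C@H]2OC(C)=O)cc1` is not yet measured; it differs from compound 3 by hydrogen in place of hydroxymethyl on a saturated ring carbon, the same change as that from compound 1 to compound 2, made at the same place on the sugar ring. The earlier instance of this change gave no readable size because both ends of a step that the two limits leave unreadable from compound 1 to compound 2 are limits, so nothing known here says whether removing the hydroxymethyl helps or hurts. The expectation for the step of a 1.4-fold higher number from compound 3 to compound 4 (0.16 log units; within the scatter) is accordingly close to no change, with wide uncertainty. Compound 4 is estimated at 110000 nM in this assay, within a range of 40000 nM to 300000 nM, and it may well return only a limit.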

Compound 4, half-maximal effective concentration: 36700 nM
Estimate against measurement, compound 4: 3.0-fold (0.48 log units) above, and the stated range ends above it.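

In this assay, hydrogen in place of hydroxymethyl on a saturated ring carbon now has a readable size, a 2.1-fold lower number from compound 3 to compound 4 (0.32 log units; beyond the scatter), whereas its earlier instance on the core of compound 1 cannot be read, and nothing here shows whether the size carries from one core to the other. From the compounds shown here alone, the ((4-methoxyphenyl)carbonyl)amino change is the one that can be followed on both sugars, and the new instance gives an at least 5.4-fold lower number from compound 2 to compound 4 (0.73 log units; beyond the scatter), pointing the same way as the earlier one: the same change on two cores in this assay, an at least 2.6-fold lower number (0.41 log units; beyond the scatter) from compound 1 to compound 3 and an at least 5.4-fold lower number (0.73 log units; beyond the scatter) from compound 2 to compound 4; the limit leaves it open whether they differ Compound 2 gives only a limit, > 200000 nM, and the full size of that step stays unknown.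

The compounds shown leave open whether the lower number depends on the ((4-methoxyphenyl)carbonyl)amino group as a whole, since no simpler group on that aromatic carbon, such as an amine or an acetylamino group, stands beside it. They also leave open what a methyl group or a longer chain such as hydroxyethyl would do in place of hydroxymethyl on the sugar ring, and whether hydroxy groups in place of the acetoxy groups would change the numbers on either core.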